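This account rests on a few compounds, and the source may have more. Where it says the series, first, only, none or still open, it means among the compounds named here.

In a functional assay on HT-29 cells (Homo sapiens) for antiproliferative activity, read by sulforhodamine B assay, with a stated time of 48 h (on this read-out higher numbers stand for weaker inhibition and lower numbers for stronger inhibition), compound 1 `O=C1NCCN1c1ccc(S(=O)(=O)Nc2ccc(Cl)cc2)cc1` gives 220 nM and compound 2 `O=C1NCCN1c1ccc(S(=O)(=O)Nc2cccc(Cl)c2)cc1` gives 55 nM, the lower of the two numbers. Compound 3 `Cc1ccc(NS(=O)(=O)c2ccc(N3CCNC3=O)cc2)c(C)c1` carries 2,4-dimethylphenyl in place of 3-chlorophenyl on a sulfonamide nitrogen. Within the data shown here, only one measured step bears on this change: a 4.0-fold lower number from compound 1 to compound 2 (0.60 log units; beyond the scatter), a modest shift with 3-chlorophenyl in place of 4-chlorophenyl. Among the measured compounds shown here, no measured compound carries 2,4-dimethylphenyl, so the guess is loose, but a similarly modest rise in this assay is expected. The expected step is a 2.7-fold higher number from compound 2 to compound 3 (0.44 log units; beyond the scatter). For compound 3 the estimated value is 150 nM, with an expected range of 40 nM to 600 nM.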

Compound 3, half-maximal inhibitory concentration: 180 nM
Compound 3: the middle estimate sits 1.2-fold (0.08 log units) below what was measured, within the range that was stated.
By their numbers in this assay, from the lowest: compound 2; then compounds 3 and 1 (each within the scatter of the next).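

In this assay, replacing 3-chlorophenyl on the sulfonamide nitrogen with 2,4-dimethylphenyl gives a 3.3-fold higher number from compound 2 to compound 3 (0.51 log units; beyond the scatter), so a group without chlorine does not match compound 2 here. The other comparison, a 1.2-fold lower number from compound 1 to compound 3 (0.09 log units; within the scatter), lies within the scatter, so 2,4-dimethylphenyl and 4-chlorophenyl cannot be told apart at this position. No measurement at hand gives a reason for these differences. Still open, from the compounds shown here alone, is how this position responds to an unsubstituted phenyl, or to a phenyl ring bearing an amine or a carboxylic acid.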